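A few compounds are considered here, and "the series" means these few. Any claim that something is new, unique, unknown or untested is made for them only; others in the source may bear on it.

Series in a functional assay on HepG2 cells (Homo sapiens) for cytotoxicity, read by MTT assay, with a stated time of 72 h; a lower number here means a stronger inhibitor, a higher number a weaker inhibitor:
- compound 1 `Cc1ccc(-c2nc3cc(NC(=O)CN4CCCCC4)ccc3[nH]2)cc1`: > 50000 nM, a limit of the assay
- compound 2 `CCN1CCN(CC(=O)Nc2ccc3[nH]c(-c4ccc(C)cc4)nc3c2)CC1`: 31900 nM
- compound 3 `Cc1ccc(-c2nc3cc(NC(=O)CN4CCCC4)ccc3[nH]2)cc1`: not yet measured

For the measured compounds named here, compound 2 holds the only true number so far, since compound 1 gives only a limit. Compound 3 differs from compound 2 as follows: pyrrolidin-1-yl in place of 4-ethylpiperazin-1-yl on a saturated chain carbon bound to a carbonyl carbon. Going by the values given here, one measured step bears on this place: an at least 1.5-fold lower number from compound 1 to compound 2 (0.19 log units; that floor lies within the scatter). That step gives no firm size, so no change beyond the scatter is expected, and an estimated 1.3-fold higher number from compound 2 to compound 3 (0.10 log units; within the scatter) leans only slightly towards weaker inhibition. Compound 3 is expected at 40000 nM, with an estimated range of 18000 nM to 70000 nM in this assay.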

Compound 3, half-maximal inhibitory concentration: > 50000 nM
Compound 3: no number, only a limit; the forecaster's own chance of this, stated with the estimate: 40%; middle value at least 1.2-fold (0.09 log units) from the limit.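

In this assay, for the compounds shown here, pyrrolidin-1-yl on the saturated chain carbon bound to a carbonyl carbon gives an at least 1.5-fold higher number from compound 2 to compound 3 (0.19 log units; that floor lies within the scatter), so a second ring change at this place also yields only a floor, and compound 2 remains the only compound with a true number. The step between compound 1 and compound 3 cannot be read, as both values are limits. Both of these compounds end at the same reading: the limit of > 50000 nM in this assay, at which 2 of the 3 values shown sit.

Going by these compounds, how far compound 1 and compound 3 lie past that limit remains open. Also open, on these data alone, is whether an open-chain amine such as diethylamino, or a morpholine ring, at this place gives a true number in this assay.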